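Ring expansion on the amide side chain, pyrrolidine to piperidine

This account rests on a few compounds, and the source may have more. Where it says the series, first, only, none or still open, it means among the compounds named here.

Among the compounds with values here, compound 2 `CC1=C(C(C)C(=O)NCCN2CCCC2)c2cc(F)ccc2/C1=C\c1ccc([S+](C)[O-])cc1` gives 13700 nM in a functional assay on HT-29 cells (Homo sapiens) for inhibition, read by CellTiter-Glo, with a stated time of 72 h; on this read-out higher numbers stand for lower toxicity in this test and lower numbers for higher toxicity in this test; its only neighbour, compound 1 `CC1=C(C(C)C(=O)NCCN(C)C)c2cc(F)ccc2/C1=C\c1ccc([S+](C)[O-])cc1`, gives 12700 nM, the two standing within the scatter of each other, as a 1.1-fold higher number from compound 1 to compound 2 (0.03 log units; within the scatter) shows. Compound 3 `CC1=C(C(C)C(=O)NCCN2CCCCC2)c2cc(F)ccc2/C1=C\c1ccc([S+](C)[O-])cc1` differs from compound 2 by piperidin-1-yl in place of pyrrolidin-1-yl on a saturated chain carbon, two bonds along the chain from an amide-type nitrogen. Within the data shown here, the one measured step at this position, dimethylamino to pyrrolidin-1-yl, stayed within the scatter, so for compound 3 no step beyond the scatter is expected in this assay, that is a 1.0-fold higher number from compound 2 to compound 3 (0.01 log units; within the scatter). Compound 3 is therefore estimated at 14000 nM, with a range of 7000 nM to 28000 nM.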

Compound 3, half-maximal cytotoxic concentration: 9670 nM
For compound 3 the middle estimate is 1.4-fold (0.16 log units) above the measured one; measured number inside the range.
By their numbers in this assay, from the lowest: compounds 3, 1 and 2 (each within the scatter of the next).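

In this assay the change from pyrrolidin-1-yl to piperidin-1-yl gives a 1.4-fold lower number from compound 2 to compound 3 (0.15 log units; within the scatter) and the change from dimethylamino to piperidin-1-yl gives a 1.3-fold lower number from compound 1 to compound 3 (0.12 log units; within the scatter) in the same series. All three amines at this place, on a saturated chain carbon, two bonds along the chain from an amide-type nitrogen, therefore stand within the scatter of one another, now including both ring sizes. The data given offer no explanation for these small differences.

Still open, as far as these compounds go, is whether a morpholine or a piperazine in place of piperidin-1-yl would stay within the scatter. Also open, from the compounds shown here alone, is what a longer chain between the amide nitrogen and the amine would do.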